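Methoxy for Methyl: Expecting the Value of Compound 4

A few compounds are considered here, and "the series" means these few. Any claim that something is new, unique, unknown or untested is made for them only; others in the source may bear on it.

Measured so far:
compound 1 `COc1ccc(-c2nn(-c3ccccc3)cc2CNc2ccc(F)cc2)cc1`: 6580 nM
compound 2 `Cc1ccc(-c2nn(-c3ccccc3)cc2CNc2ccc(F)cc2)cc1`: 5670 nM
compound 3 `Cc1ccc(-c2nn(-c3ccccc3)cc2CNc2ccc(Cl)cc2)cc1`: 6010 nM

These three numbers come from a functional assay on B16-F10 cells (Mus musculus) for antiproliferative activity, read by MTT assay, with a stated time of 48 h; a lower number here means a stronger inhibitor, a higher number a weaker inhibitor. Compound 1 and compound 2 share one core and differ only in the change (methoxy in place of methyl on an aromatic carbon); that change gave a 1.2-fold higher number from compound 2 to compound 1 (0.06 log units; within the scatter). The cores of compound 2 and compound 3 differ by chloro in place of fluoro on an aromatic carbon, and that change gave a 1.1-fold higher number from compound 2 to compound 3 (0.03 log units; within the scatter). Among the compounds with values here, every one of the three values lies within the usual scatter of the others, so no compound among them can be called the stronger or weaker inhibitor.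

Compound 4 `COc1ccc(-c2nn(-c3ccccc3)cc2CNc2ccc(Cl)cc2)cc1` has not yet been measured in this assay. It differs from compound 3 by methoxy in place of methyl on an aromatic carbon. The group that leaves, the group that enters and the place where this happens are the same as in the change from compound 2 to compound 1, so this is the same change made on a different core. That earlier change gave a 1.2-fold higher number from compound 2 to compound 1 (0.06 log units; within the scatter), a step within the scatter, and a step of the same size is expected here. Compound 4 is therefore expected to show a 1.2-fold higher number from compound 3 to compound 4 (0.07 log units; within the scatter). Compound 4 is estimated at 7000 nM, with a likely range from 3500 nM to 14000 nM.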

Compound 4, half-maximal inhibitory concentration: 7180 nM
The estimate for compound 4 lay 1.0-fold (0.01 log units) below the measured number; the range from low to high includes it.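

In this assay, methoxy in place of methyl on the core that carries chloro comes with a 1.2-fold higher number from compound 3 to compound 4 (0.08 log units; within the scatter), and this step matches the one seen on the core that carries fluoro: the same change on two cores in this assay, a 1.2-fold higher number (0.06 log units; within the scatter) from compound 2 to compound 1 and a 1.2-fold higher number (0.08 log units; within the scatter) from compound 3 to compound 4, 1.0-fold (0.01 log units) apart, within the scatter of two such steps. Chloro in place of fluoro, on the cores that carry methoxy, comes with a 1.1-fold higher number from compound 1 to compound 4 (0.04 log units; within the scatter), and this step likewise matches its earlier counterpart: the same change on two cores in this assay, a 1.1-fold higher number (0.03 log units; within the scatter) from compound 2 to compound 3 and a 1.1-fold higher number (0.04 log units; within the scatter) from compound 1 to compound 4, 1.0-fold (0.01 log units) apart, within the scatter of two such steps. Within the data shown here, each change therefore reads the same on both cores, but every step lies within the scatter, so this shows only that neither change produced a measurable difference here; it does not show that either change has a real effect that carries over, and two cores say nothing about other cores.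

Going by these compounds, all four compounds sit within the scatter of one another, so it remains open what an amine, a hydroxyl or a longer chain such as ethoxy would do in place of the methoxy. Also open, on these data alone, is whether any group at either site can produce a step beyond the scatter.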